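The compounds below may be only part of what the source reports. "The series", "measured", "known", "first", "only" and "open" are said of these compounds alone.

Three compounds share one core and differ only in the substituted phenyl group on an aromatic nitrogen. In a functional assay on OVCAR-3 cells (Homo sapiens) for inhibition, read by MTT assay, with a stated time of 24 h (a higher number here means a weaker inhibitor, a lower number a stronger inhibitor), compound 1 `CC1(C)[C@H]2CC[C@]1(C)N(Cc1cn(-c3ccccc3Br)nn1)C(=O)C2` gives 140 nM, compound 2 `CC1(C)[C@H]2CC[C@]1(C)N(Cc1cn(-c3ccc(C#N)cc3)nn1)C(=O)C2` gives 380 nM, and compound 3 `CC1(C)[C@H]2CC[C@]1(C)N(Cc1cn(-c3cccc(C#N)c3)nn1)C(=O)C2` gives 230 nM. Compound 3 stands mid-range on these numbers, but it cannot be told apart from either of the others, with a 1.6-fold higher number from compound 1 to compound 3 (0.22 log units; within the scatter) and a 1.7-fold lower number from compound 2 to compound 3 (0.22 log units; within the scatter). Only the outer pair separates, with a 2.7-fold higher number from compound 1 to compound 2 (0.43 log units; beyond the scatter).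

The next compound is compound 4 `CC1(C)[C@H]2CC[C@]1(C)N(Cc1cn(-c3ccccc3F)nn1)C(=O)C2`, which carries 2-fluorophenyl in place of 3-cyanophenyl on an aromatic nitrogen. Within the data shown here, no measured compound carries fluorine, so the swap itself is untested. The nearest guide is compound 1 at 140 nM, whose 2-bromophenyl group differs from 2-fluorophenyl only in the halogen. The measured steps among these three groups are modest, so this assay is expected to show a small shift toward compound 1 and no step beyond the scatter. The expected change is a 1.3-fold lower number from compound 3 to compound 4 (0.11 log units; within the scatter). For compound 4 the estimated value is 180 nM, with an expected range of 80 nM to 400 nM.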

Compound 4, half-maximal inhibitory concentration: 300 nM
Beside the measured number, compound 4's estimate is 1.7-fold (0.22 log units) below it, and the stated range covers the measured number.
By their numbers in this assay, from the lowest: compounds 1, 3, 4 and 2 (each within the scatter of the next, the first and the last beyond it).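

Among these compounds, until now, the only pair that separated in this assay set the 2-bromophenyl compound against a cyanophenyl one, but changing only the halogen also separates, with a 2.1-fold higher number from compound 1 to compound 4 (0.33 log units; beyond the scatter) for fluoro in place of bromo on an aromatic carbon. Which halogen the phenyl ring carries therefore counts, and having a halogen there does not by itself keep the number of compound 1. With a 1.3-fold higher number from compound 3 to compound 4 (0.12 log units; within the scatter) and a 1.3-fold lower number from compound 2 to compound 4 (0.10 log units; within the scatter) both inside the scatter, compound 4 cannot be told apart from either nitrile compound, so the 2-fluorophenyl and cyanophenyl groups cannot be ranked against one another in these data.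

The compounds shown leave open whether the number follows the halogen in a regular way or the bromo compound is a special case, which a chloro or iodo group in place of the bromo, a methyl group, or a plain phenyl ring with no substituent would help to settle. Nothing measured here accounts for the gap between the bromo and fluoro compounds.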